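This account rests on a few compounds, and the source may have more. Where it says the series, first, only, none or still open, it means among the compounds named here.

Measured so far:
Compound 1, `CCn1c(C(=O)NCCC(=O)OC)ccc1C(CC)(CC)c1ccc(OCS(=O)(=O)c2ccccc2)c(C)c1`: 40400 nM
Compound 2, `CCn1c(C(=O)N[C@@H](CC(=O)OC)C(=O)OC)ccc1C(CC)(CC)c1ccc(OCS(=O)(=O)c2ccccc2)c(C)c1`: 6490 nM

In a functional assay on PC-3 cells (Homo sapiens) for antiproliferative activity, read by MTT assay, with a stated time of 24 h (on this read-out higher numbers stand for weaker inhibition and lower numbers for stronger inhibition), compound 1 stands at the higher of the two numbers; compound 2 lies a 6.2-fold lower number from compound 1 to compound 2 (0.79 log units; beyond the scatter) from it. Compound 3, `CCn1c(C(=O)NC2(CO)CC2)ccc1C(CC)(CC)c1ccc(OCS(=O)(=O)c2ccccc2)c(C)c1`, has not yet been measured. It differs from compound 1 by 1-(hydroxymethyl)cyclopropyl in place of 2-(methoxycarbonyl)ethyl on an amide-type nitrogen, so the whole 2-(methoxycarbonyl)ethyl group is exchanged rather than decorated. Among the compounds with values here, the one measured step, a 6.2-fold lower number from compound 1 to compound 2 (0.79 log units; beyond the scatter), touches the same amide side chain and shows that changes there can move the number beyond the scatter, but it keeps the ester that compound 3 loses, so it does not directly foretell this change. A modest step is therefore expected for compound 3, more likely downward than upward, though with wide uncertainty. The estimate for compound 3 in this assay is 20000 nM, with a range from 5000 nM to 80000 nM, which amounts to an expected step of a 2.0-fold lower number from compound 1 to compound 3 (0.31 log units; beyond the scatter).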

Compound 3, half-maximal inhibitory concentration: 3560 nM
The estimate for compound 3 lay 5.6-fold (0.75 log units) above the measured number; measured number below the stated range.
By their numbers in this assay, from the lowest: compounds 3 and 2 (each within the scatter of the next); then compound 1.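

At this amide-type nitrogen, the methoxycarbonyl groups are not required for the lower numbers in this assay: exchanging the whole 2-(methoxycarbonyl)ethyl group for 1-(hydroxymethyl)cyclopropyl gives an 11-fold lower number from compound 1 to compound 3 (1.05 log units; beyond the scatter), a larger step than the earlier addition of a second methoxycarbonyl group. Two quite different side chains, one with two methoxycarbonyl groups and one with none, also end up level, with a 1.8-fold lower number from compound 2 to compound 3 (0.26 log units; within the scatter). Nothing available accounts for the size of this step or for that match.

These compounds do not separate the contribution of the three-membered ring from that of the hydroxymethyl group, since both enter together. A 2-hydroxyethyl chain or a plain cyclopropyl on this nitrogen would address that, while a carboxylic acid in place of the methoxycarbonyl remains an open question.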